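Fluorinated benzyl nucleosides and antiproliferative activity

The source may hold more compounds than are shown below. What is called first, only, known or untested is meant among the compounds shown, and "the series" means these compounds.

Compound 1 `OC[C@H]1O[C@@H](n2cnc3c(NCc4ccccc4F)ncnc32)[C@H](O)[C@@H]1O`: > 166000 nM
Compound 2 `OC[C@H]1O[C@@H](n2cnc3c(NCc4c(F)ccc(F)c4F)ncnc32)[C@H](O)[C@@H]1O`: "not determined" (no result reported)

In a functional assay on HOS cells (Homo sapiens) for antiproliferative activity, with a stated time of 72 h (a lower number here means a stronger inhibitor, a higher number a weaker inhibitor), compound 1 reaches only a limit, > 166000 nM, and not a number. Compound 2 has no result in this assay, so nothing measured places it on the scale. Compound 3 `OC[C@H]1O[C@@H](n2cnc3c(NCc4ccc(C(F)(F)F)cc4)ncnc32)[C@H](O)[C@@H]1O` carries 4-(trifluoromethyl)phenyl in place of 2,3,6-trifluorophenyl on a saturated chain carbon bound to a nitrogen on an aromatic ring. Among the measured compounds shown here, with no measured step to lean on, and with compound 1 sitting at the limit of > 166000 nM in this assay, at which 1 of the 2 values shown sits, no change beyond the usual scatter is expected from compound 2 to compound 3 in this assay. Compound 3 is therefore expected to give about 150000 nM, within 30000 nM to 500000 nM.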

Compound 3, half-maximal inhibitory concentration: > 166000 nM
Compound 3 was reported as a limit (the forecaster's own chance of this, stated with the estimate: 80%); middle value at least 1.1-fold (0.04 log units) from the limit.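

Among the compounds shown here, compound 1 and compound 3 are each reported only as a limit, so no step between them can be read. The compounds shown leave open whether swapping 2-fluorophenyl for 4-(trifluoromethyl)phenyl changes antiproliferative strength at all.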